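Working notes: compound 1 to compound 3

The compounds below may be only part of what the source reports. "The series", "measured", "known", "first", "only" and "open" are said of these compounds alone.

The series is followed in a functional assay on CFPAC-1 cells (Homo sapiens) for antiproliferative activity, read by MTT assay, with a stated time of 72 h; a higher number here means a weaker inhibitor, a lower number a stronger inhibitor. Compound 1 (`O=C1O/C(=C\Cn2cc(-c3ccc(Br)cc3)nn2)C(OCc2ccccc2)=C1OCc1ccccc1`) gives > 100000 nM in this assay, which is a limit of the measurement and not a number. For the measured compounds named here, compound 2 (`CCCCCCCCCCc1cn(C[C@H](O)[C@H]2OC(=O)C(OCc3ccccc3)=C2OCc2ccccc2)nn1`) is the only member with a numerical value, giving 40300 nM in this assay. Compound 1 therefore stands at the weak end of what is known, sitting at the limit of > 100000 nM in this assay, at which 1 of the 2 values shown sits. Going by the values given here, no measured pair that differs in one place is available, so no step size has been observed.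

Compound 3 (`COc1ccccc1-c1cn(C/C=C2\OC(=O)C(OCc3ccccc3)=C2OCc2ccccc2)nn1`) is the next candidate for this assay. It differs from compound 1 by 2-methoxyphenyl in place of 4-bromophenyl on an aromatic carbon. With compound 1 at a limit, the step from compound 1 to compound 3 is expected to be about an at least 1.1-fold lower number from compound 1 to compound 3 (0.04 log units; that floor lies within the scatter), which is none beyond the scatter in any known direction. Compound 3 is accordingly expected to give about 90000 nM in this assay, with a range from 30000 nM to 300000 nM, and a fair chance that only a limit is again reported.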

Compound 3, half-maximal inhibitory concentration: > 100000 nM
Compound 3 gave a limit, no number; the forecaster's own chance of this, stated with the estimate: 60%; at least 1.1-fold (0.04 log units) between middle value and limit.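

Compound 1 and compound 3 both end at a limit, so the step between them, 2-methoxyphenyl in place of 4-bromophenyl on an aromatic carbon, cannot be read: the limit of > 100000 nM in this assay, at which 2 of the 3 values shown sit.

The compounds shown leave open whether this exchange shifts the read-out in this assay at all, and in which direction.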